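This account rests on a few compounds, and the source may have more. Where it says the series, first, only, none or still open, it means among the compounds named here.

Measured so far:
compound 1, `CCCCc1nc(=O)c(S(=O)(=O)c2ccc(-n3ccccc3=O)cc2)c(O)n1-c1c(OC)cccc1OC`: 63%
compound 2, `CCCCc1nc(=O)c(S(=O)(=O)c2ccc(-n3cc(Cl)ccc3=O)cc2)c(O)n1-c1c(OC)cccc1OC`: 100%
compound 3, `CCCCc1[nH]c(=O)c(S(=O)(=O)c2ccc(-n3ccccc3=O)cc2)c(O)c1-c1c(OC)cccc1OC`: 75%

All three were tested in an ADME assay on microsomes from liver (Mus musculus) for metabolic stability, using NADPH, with a stated time of 10 min; a lower number here means that less of the compound is left, a higher number that more of the compound is left. Compound 2 differs from compound 1 by one change, (chloro in place of hydrogen on an aromatic carbon), and this change gave a number 37 percentage points higher from compound 1 to compound 2 (beyond the scatter). Compound 3 has a different core from compound 1; how the two cores differ is not broken down here. Compound 4, `CCCCc1[nH]c(=O)c(S(=O)(=O)c2ccc(-n3cc(Cl)ccc3=O)cc2)c(O)c1-c1c(OC)cccc1OC`, is not yet measured. It differs from compound 3 by the same change, (chloro in place of hydrogen on an aromatic carbon), at the same place. Carrying the earlier step over, a rise is expected, though a smaller one, because in this assay compound 3 already gives 75% and the read-out cannot go beyond complete recovery; the expected step is a number 20 percentage points higher from compound 3 to compound 4 (beyond the scatter). For compound 4 the estimate in this assay is 95%, with a likely range from 80% to 100%.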

Compound 4, percent of the compound remaining: 64%
Estimate against measurement, compound 4: 31 percentage points above; measured number below the stated range.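

In this assay chloro in place of hydrogen on an aromatic carbon gave a number 11 percentage points lower from compound 3 to compound 4 (beyond the scatter) and thus no rise on this core. A step measured on one core therefore cannot simply be carried over to another in this series, although two pairs do not show which difference between the cores matters or how any further core would respond. Set side by side, the two steps differ in direction and in size: the same change on two cores in this assay, a number 37 percentage points higher (beyond the scatter) from compound 1 to compound 2 and a number 11 percentage points lower (beyond the scatter) from compound 3 to compound 4, 48 percentage points apart, beyond the scatter of two such steps

From the compounds shown here alone, what stays open is whether another group at the same place, such as fluoro, methyl or methoxy, would also move the number in opposite directions on the two cores.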